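Moving a chlorine around the ring: what changes for cells

A few compounds are considered here, and "the series" means these few. Any claim that something is new, unique, unknown or untested is made for them only; others in the source may bear on it.

Within the data shown here, compound 1 `CC(C)CCc1sc(NC(=O)c2cc(NC(=O)c3cc(NC(=N)c4ccc(Cl)cc4)cn3C)cn2C)nc1C(=O)NCCCN(C)C` was tested in an ADME assay on HEK293 cells (Homo sapiens) for cytotoxicity, read by fluorescence and resazurin assay, with a stated time of 20 h; on this read-out lower numbers stand for higher toxicity in this test and higher numbers for lower toxicity in this test; in this assay compound 1 gives 10 ug/mL, the only number the study shows. Compound 2 `CN(C)CCCNC(=O)c1cc(NC(=O)c2cc(NC(=O)c3cc(NC(=N)c4ccccc4)cn3C)cn2C)cn1C` is a close relative, but in this assay compound 2 gives "not determined" (no result reported), so compound 1 stands alone. Compound 3 `CC(C)CCc1sc(NC(=O)c2cc(NC(=O)c3cc(NC(=N)c4cccc(Cl)c4)cn3C)cn2C)nc1C(=O)NCCCN(C)C` has the same atoms joined differently: 3-chlorophenyl in place of 4-chlorophenyl on a carbon with a double bond to nitrogen. Among the measured compounds shown here, with no step between measured compounds to learn from, a small change is expected, none beyond the usual scatter, as no change at the digits printed from compound 1 to compound 3 (within the scatter). Compound 3 is therefore estimated at 10 ug/mL, in the range 5 ug/mL to 20 ug/mL.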

Compound 3, half-maximal cytotoxic concentration: 9.2 ug/mL
The estimate for compound 3 lay 1.1-fold (0.04 log units) above the measured number; the measured number falls inside the stated range.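

In this assay, 3-chlorophenyl in place of 4-chlorophenyl on a carbon with a double bond to nitrogen gives a 1.1-fold lower number from compound 1 to compound 3 (0.04 log units; within the scatter), the first comparison available here. Where the chlorine sits on this ring therefore makes no difference that this test can separate, at least between these two ring positions. Nothing at hand offers an explanation for this result. Still open, going by these compounds, is how the read-out responds to a different group on this ring, such as a methoxy group or an amine in place of the chlorine.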